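A few compounds are considered here, and "the series" means these few. Any claim that something is new, unique, unknown or untested is made for them only; others in the source may bear on it.

Three compounds built on one shared core were tested in a functional assay on A549 cells (Homo sapiens) for cytotoxicity, read by MTT assay, with a stated time of 24 h; on this read-out higher numbers stand for weaker inhibition and lower numbers for stronger inhibition. Compound 1 `C=CC1=C(C(=O)Nc2ccccc2)C(c2ccc(Cl)c(Cl)c2)OC1` gives only a limit of the assay, > 100000 nM. Compound 2 `C=CC1=C(C(=O)Nc2ccccc2)C(c2ccc(F)cc2)OC1` likewise gives only a limit, > 100000 nM. Compound 3 `C=CC1=C(C(=O)NCc2ccccc2)C(c2ccc(F)cc2)OC1` also gives only a limit, > 100000 nM. The cores of compound 2 and compound 3 differ by benzyl in place of phenyl on an amide-type nitrogen, a step that the two limits leave unreadable from compound 2 to compound 3. From compound 2 to compound 1 the change is 3,4-dichlorophenyl in place of 4-fluorophenyl on a saturated ring carbon, a step that the two limits leave unreadable from compound 2 to compound 1 that stays unreadable because of the limit of > 100000 nM in this assay, at which 3 of the 3 values shown sit. Compound 4 `C=CC1=C(C(=O)NCc2ccccc2)C(c2ccc(Cl)c(Cl)c2)OC1` arises from compound 3 by the same kind of change, (3,4-dichlorophenyl in place of 4-fluorophenyl on a saturated ring carbon); around the place, one description speaks of the ring atom that bears a large group and the other of the ring atom that bears a group of 9 heavy atoms. Because the earlier step that the two limits leave unreadable from compound 2 to compound 1 could not be read, the expected step is a step that the limit leaves unreadable from compound 3 to compound 4. Compound 4 is estimated at 150000 nM, most likely again only a limit.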

Compound 4, half-maximal inhibitory concentration: > 100000 nM
Compound 4 ended at the assay's limit (the forecaster's own chance of this, stated with the estimate: 85%); the middle value lies beyond the limit too.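

No step can be read among compound 1, compound 2, compound 3 and compound 4, because all four stop at the same limit: the limit of > 100000 nM in this assay, at which 4 of the 4 values shown sit.

The compounds shown leave open whether benzyl in place of phenyl, or 3,4-dichlorophenyl in place of 4-fluorophenyl, changes cytotoxicity at all.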